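This account rests on a few compounds, and the source may have more. Where it says the series, first, only, none or still open, it means among the compounds named here.

Among the compounds with values here, in a functional assay on MCF7 cells (Homo sapiens) for antiproliferative activity, read by sulforhodamine B assay, with a stated time of 48 h (a lower number here means a stronger inhibitor, a higher number a weaker inhibitor), compound 1 `O=C1NCCN1c1ccc(S(=O)(=O)Nc2ccccc2)cc1` gives 470 nM, and compound 2 `O=C1NCCN1c1ccc(S(=O)(=O)Nc2ccc(Cl)cc2)cc1` gives 170 nM, the lower of the two numbers so far. Within the data shown here, the only measured step is a 2.8-fold lower number from compound 1 to compound 2 (0.44 log units; beyond the scatter), a modest change with chloro in place of hydrogen on an aromatic carbon. Compound 3 `CCCCCc1ccc(NS(=O)(=O)c2ccc(N3CCNC3=O)cc2)cc1` carries pentyl in place of chloro on an aromatic carbon, para to a large group: pentyl in place of chloro on an aromatic carbon. Among the measured compounds shown here, the one measured step bears on this change only indirectly, as no compound with pentyl has been measured and hydrogen, not pentyl, is the comparison there. No firm direction can be drawn from it, so the expectation in this assay is a step no larger than that modest one, most likely none beyond the scatter. The expected step is a 1.2-fold higher number from compound 2 to compound 3 (0.07 log units; within the scatter). For compound 3 the estimated value is 200 nM, with an expected range of 60 nM to 700 nM.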

Compound 3, half-maximal inhibitory concentration: > 1000 nM
Compound 3: a limit, no number (the forecaster's own chance of this, stated with the estimate: 3%); middle value at least 5.0-fold (0.69 log units) away from the limit.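

Compound 3 stands at a limit of the assay, not at a number: the limit of > 1000 nM in this assay, at which 1 of the 3 values shown sits.

Even so, the aromatic carbon para to a large group now proves sensitive in both directions in this assay: pentyl in place of chloro gives an at least 5.8-fold higher number from compound 2 to compound 3 (0.76 log units; beyond the scatter), and pentyl in place of hydrogen gives an at least 2.1-fold higher number from compound 1 to compound 3 (0.32 log units; beyond the scatter). Chloro lowers the number relative to hydrogen, whereas pentyl raises it, so a substituent here does not simply carry the gain seen with chloro.

A methyl or propyl group on this carbon would show whether the rise sets in gradually with chain length or only at pentyl. As far as these compounds go, whether a chain ending in an amine or a carboxylic acid behaves like pentyl also remains open.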